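The source may hold more compounds than are shown below. What is called first, only, known or untested is meant among the compounds shown, and "the series" means these compounds.

Compound 1 `COc1ccc(/C=C\c2cc(OC)c(OC)c(OC)c2)cc1OCc1ccc(CNC(C)(C)C(=O)O)cc1`: > 50000 nM
Compound 2 `COc1ccc(/C=C\c2cc(OC)c(OC)c(OC)c2)cc1OCc1ccc(CN2CCCCC2C(=O)O)cc1`: > 50000 nM

Both entries are limits of an ADME assay on NCM460 cells (Homo sapiens) for cytotoxicity, read by CCK-8 assay, with a stated time of 48 h (on this read-out lower numbers stand for stronger inhibition and higher numbers for weaker inhibition), not numbers. For the measured compounds named here, compound 2 is therefore known only as a limit, and the single other value, that of compound 1, is a limit as well: the limit of > 50000 nM in this assay, at which 2 of the 2 values shown sit.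

Compound 3 `COc1ccc(/C=C\c2cc(OC)c(OC)c(OC)c2)cc1OCc1ccc(CN2CCCCC2C(=O)NCCNC(=O)OC(C)(C)C)cc1` differs from compound 2 at the carbonyl carbon, where (2-((tert-butoxycarbonyl)amino)ethyl)amino takes the place of hydroxy: (2-((tert-butoxycarbonyl)amino)ethyl)amino in place of hydroxy on a carbonyl carbon. Going by the values given here, the only measured step is a step that the two limits leave unreadable from compound 1 to compound 2, so no size carries over to this change. Compounds 1 and 2 both keep the hydroxy on the carbonyl carbon, and neither shows what its replacement does.

Any readable shift expected in this assay is toward lower numbers, since compound 2 gives the limit > 50000 nM. The estimated change is an at least 2.0-fold lower number from compound 2 to compound 3 (0.30 log units; that floor lies within the scatter), held loosely, and a further limit remains quite possible. For compound 3 the estimate is 25000 nM, with an expected range of 3000 nM to 50000 nM.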

Compound 3, half-maximal inhibitory concentration: 28000 nM
Compound 3: the middle estimate sits 1.1-fold (0.05 log units) below what was measured; measured number inside the range.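

In this assay, for the compounds shown here, compound 3 gives 28000 nM, the first true number in this set, so the carbonyl carbon on the saturated ring carbon is a place where a change can yield a true number. As far as these compounds go, the change from hydroxy to (2-((tert-butoxycarbonyl)amino)ethyl)amino is read as an at least 1.7-fold lower number from compound 2 to compound 3 (0.25 log units; that floor lies within the scatter); this is only a floor, it lies within the scatter, and the true size of the step stays unknown. Compound 3 therefore stands apart from the two carboxylic acids only as a number against limits, and the acids themselves stay unresolved: the limit of > 50000 nM in this assay, at which 2 of the 3 values shown sit.

From the compounds shown here alone, the step from compound 1 to compound 2 cannot be read, so the two carboxylic acid side chains give no ranking, and whether the same replacement on compound 1 would act alike stays open. Also open, going by these compounds, is how much of the step belongs to the amide link and how much to the tert-butoxycarbonyl end, a question that a free primary amine at the end of the ethyl chain, or a longer chain in its place, would address.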